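Methylcarbamoyl added to compound 1: an expected modest gain

The source may hold more compounds than are shown below. What is called first, only, known or untested is meant among the compounds shown, and "the series" means these compounds.

Compound 1, `CC[C@@H]1C(=O)N(C)c2cnc(-n3ccc4ccccc43)nc2N1C1CCCC1`: 355 nM
Compound 2, `CC[C@@H]1C(=O)N(C)c2cnc(Nc3ccc(S(N)(=O)=O)cc3)nc2N1C1CCCC1`: 10.2 nM

Both compounds were tested in an assay for inhibition of serine/threonine-protein kinase PLK2 (Homo sapiens), read by FRET and Z'-LYTE, with a stated time of 1 h; on this read-out higher numbers stand for weaker inhibition and lower numbers for stronger inhibition. Compound 1 gives the highest of the two numbers; compound 2 gives a far lower number, a gap beyond the usual scatter. Compound 3, `CC[C@@H]1C(=O)N(C)c2cnc(-n3ccc4cc(C(=O)NC)ccc43)nc2N1C1CCCC1`, has not yet been measured. It differs from compound 1 in one place: methylcarbamoyl in place of hydrogen on an aromatic carbon. Going by the values given here, no measured pair shows this change, so its effect is open. The step of a 2.4-fold lower number from compound 1 to compound 3 (0.37 log units; beyond the scatter) is expected to be a modest gain, a lower number, since compound 1 starts from 355 nM with room to improve. Compound 3 is estimated at 150 nM, between 40 nM and 600 nM.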

Compound 3, half-maximal inhibitory concentration: 8.6 nM
For compound 3 the middle estimate is 17-fold (1.24 log units) above the measured one, and the stated range ends above it.
By their numbers in this assay, from the lowest: compounds 3 and 2 (each within the scatter of the next); then compound 1.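

Methylcarbamoyl in place of hydrogen on this aromatic carbon gives a 41-fold lower number from compound 1 to compound 3 (1.62 log units; beyond the scatter) and so marks this position as highly sensitive to substitution. Before this result, no pair of compounds showed what any change at this position could do. Nothing measured here explains why the step is so large.

Going by these compounds, it remains open whether the whole methylcarbamoyl group is needed, or whether a carboxylic acid or a longer ethylcarbamoyl group on the same carbon would give a similar step. On these data alone, how the same change behaves on other carbons of this ring also remains open.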